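The compounds below may be only part of what the source reports. "The series", "measured", "known", "first", "only" and "open" are said of these compounds alone.

Compound 1 `C/C(=N\Cc1cccnc1)c1c(O)c2ccccc2oc1=O`: 17000 nM
Compound 2 `C/C(=N\CCO)c1c(O)c2ccccc2[nH]c1=O`: >= 100000 nM

Among the measured compounds shown here, in an assay on isolated protein for inhibition of myosin-2 (Bos taurus), read by spectrophotometry, with a stated time of 24 min (on this read-out higher numbers stand for weaker inhibition and lower numbers for stronger inhibition), compound 1 gives 17000 nM, the only actual number among the two results. Compound 2 shows only a limit of the assay, >= 100000 nM, and so stands at the limit of >= 100000 nM in this assay, at which 1 of the 2 values shown sits. For the measured compounds named here, no pair of measured compounds differing in a single place exists here, so no measured step can guide the next change.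

Compound 3 `CCCCC/N=C(\C)c1c(O)c2ccccc2oc1=O` differs from compound 1 by butyl in place of pyridin-3-yl on a saturated chain carbon bound to a double-bonded nitrogen. The step from compound 1 to compound 3 is expected to be a 1.1-fold lower number from compound 1 to compound 3 (0.05 log units; within the scatter), no larger than the usual scatter. Compound 3 is therefore expected to give 15000 nM, with a likely range from 4000 nM to 60000 nM.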

Compound 3, half-maximal inhibitory concentration: 6700 nM
For compound 3 the middle estimate is 2.2-fold (0.35 log units) above the measured one; measured number inside the range.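

In this assay, butyl in place of pyridin-3-yl gives a 2.5-fold lower number from compound 1 to compound 3 (0.40 log units; beyond the scatter). Inhibition at this position therefore does not depend on the pyridin-3-yl ring: the plain chain, with no ring and no hydrogen-bond acceptor, gives the stronger inhibition of the two. Nothing measured here says why the number falls.

On these data alone, whether a longer chain or a branched chain would lower the number further remains open. Also open, as far as these compounds go, is how a phenyl ring, an amine or a carboxylic acid would compare with butyl.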